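Trifluoromethyl for methyl on the benzyl ring of compound 1

A few compounds are considered here, and "the series" means these few. Any claim that something is new, unique, unknown or untested is made for them only; others in the source may bear on it.

Measured so far:
compound 1, `C=C(Br)C(=O)Nc1cccc(/C=C2\SC(=O)N(Cc3ccc(C)cc3)C2=O)c1`, 1200 nM
compound 2, `CC(C)(C)c1ccc(CN2C(=O)S/C(=C\c3ccc(N)cc3)C2=O)cc1`, 66000 nM
compound 3, `Cc1ccc(CN2C(=O)S/C(=C\c3cccc(N)c3)C2=O)cc1`, > 250000 nM

Of the compounds shown here, three sharing one core have been tested in a functional assay on CCRF-CEM cells (Homo sapiens) for cytotoxicity, read by cell counting, with a stated time of 3 days; on this read-out lower numbers stand for stronger inhibition and higher numbers for weaker inhibition. Compound 1 gives 1200 nM and stands lowest of the two numbers; compound 2 gives 66000 nM, the nearest value. For compound 3 this assay reports only a limit, > 250000 nM. The step from compound 1 to compound 3, hydrogen in place of (1-bromoethenyl)carbonyl on a nitrogen on an aromatic ring, reads an at least 200-fold higher number from compound 1 to compound 3 (2.31 log units; beyond the scatter), and its size is known only as a bound because of the limit of > 250000 nM in this assay, at which 1 of the 3 values shown sits.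

Compound 4, `C=C(Br)C(=O)Nc1cccc(/C=C2\SC(=O)N(Cc3ccc(C(F)(F)F)cc3)C2=O)c1`, is not yet measured. It differs from compound 1 by trifluoromethyl in place of methyl on an aromatic carbon, the 4-methylphenyl becoming 4-(trifluoromethyl)phenyl. Within the data shown here, the (1-bromoethenyl)carbonyl group, whose loss produced the only measured step, is kept unchanged in compound 4. Among the measured compounds shown here, no measured pair bears on the methyl-to-trifluoromethyl exchange on this ring, so no step beyond the scatter is expected in this assay, in either direction. Compound 4 is therefore estimated at 1500 nM, within 500 nM to 5000 nM, which means an expected step of a 1.3-fold higher number from compound 1 to compound 4 (0.10 log units; within the scatter).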

Compound 4, half-maximal inhibitory concentration: 920 nM
Compound 4: the middle estimate sits 1.6-fold (0.21 log units) above what was measured; the measured number falls inside the stated range.
By their numbers in this assay, from the lowest: compounds 4 and 1 (each within the scatter of the next); then compound 2. At a limit, above all of these: compound 3.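

In this assay, the exchange of 4-methylphenyl for 4-(trifluoromethyl)phenyl gives a 1.3-fold lower number from compound 1 to compound 4 (0.12 log units; within the scatter), so with the (1-bromoethenyl)carbonyl group kept in place, this position takes trifluoromethyl in place of methyl without a step that can be told from the scatter. Among these compounds, the only step available before this one lay at the nitrogen on the other aromatic ring, and this is the first single change that reads the benzyl ring, which shows that the number in this assay does not hang on the methyl group as such. Nothing measured here speaks to why the two groups read alike.

On these data alone, whether this tolerance extends to other groups at the same place, such as a methoxy, a chlorine, an amine or a carboxylic acid, stays open, as does the effect of a longer chain there. Among the compounds shown here, also open is how a chloroacetyl or an unbrominated propenoyl group on the nitrogen would compare with (1-bromoethenyl)carbonyl, and whether removing that group from compound 4 would give a step like the one seen from compound 1.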